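Aryl substituent swap on the thiosemicarbazone series

The source may report more compounds than this note shows. Statements on the series, on what has been measured and on what is new or still open speak of the compounds shown alone.

For the measured compounds named here, compound 2 `CC1=CC[C@H](C(C)(C)NC(=S)N/N=C/c2ccccc2O)CC1` holds the only number in the set: in a functional assay on MCF7 cells (Homo sapiens) for inhibition, read by sulforhodamine B assay, with a stated time of 48 h (on this read-out higher numbers stand for weaker inhibition of growth and lower numbers for stronger inhibition of growth), compound 2 gives 2200 nM. Compound 1 `CC1=CC[C@H](C(C)(C)NC(=S)N/N=C/c2ccc(O)cc2)CC1` returns only a limit in this assay, > 100000 nM. Going by the values given here, the one measured step, an at least 45-fold lower number from compound 1 to compound 2 (1.65 log units; beyond the scatter), is large and rests on the limit (the limit of > 100000 nM in this assay, at which 1 of the 2 values shown sits). Compound 3 `CC1=CC[C@H](C(C)(C)NC(=S)N/N=C/c2cccc(Cl)c2)CC1` carries the change (3-chlorophenyl in place of 2-hydroxyphenyl on a carbon with a double bond to nitrogen). Among the compounds with values here, no measured step tests a chlorine on this ring; the earlier step shows only that shifting the hydroxy group alters the number greatly. With the hydroxy group gone, compound 3 is expected to give a higher number, estimated at 15000 nM with a range of 2000 nM to 100000 nM, meaning a 6.8-fold higher number from compound 2 to compound 3 (0.83 log units; beyond the scatter).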

Compound 3, concentration for 50% growth inhibition: 8000 nM
Compound 3: the middle estimate sits 1.9-fold (0.27 log units) above what was measured, and the stated range covers the measured number.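

In this assay, the aryl group does not need a hydroxy group to give a measured number: 3-chlorophenyl, with 0 hydrogen-bond donors, shows a 3.6-fold higher number from compound 2 to compound 3 (0.56 log units; beyond the scatter). This modest step contrasts with the large effect of replacing 4-hydroxyphenyl, seen again in an at least 12-fold lower number from compound 1 to compound 3 (1.09 log units; beyond the scatter), so compound 1 stands apart from both compound 2 and compound 3. That step is only a bound, as compound 1 sits at a limit: the limit of > 100000 nM in this assay, at which 1 of the 3 values shown sits.

The change from compound 2 to compound 3 alters both the group and its place, leaving their contributions unseparated. On these data alone, how 3-hydroxyphenyl, 2-chlorophenyl or an aryl ring carrying an amine would read remains open.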